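A few compounds are considered here, and "the series" means these few. Any claim that something is new, unique, unknown or untested is made for them only; others in the source may bear on it.

Compound 1 `COc1ccc(NC(=O)c2cccc(/C=C3\CC(=O)N(c4ccccc4)C3=O)c2)cc1` gives > 100000 nM in an ADME assay on NCM460 cells (Homo sapiens) for cytotoxicity, read by MTT assay, with a stated time of 72 h; a lower number here means a stronger inhibitor, a higher number a weaker inhibitor. Compound 2 `O=C(Nc1ccccc1)c1cccc(/C=C2\CC(=O)N(c3ccccc3)C2=O)c1` gives > 100000 nM in this assay. Compound 3 `O=C(Nc1ccc(F)cc1)c1cccc(/C=C2\CC(=O)N(c3ccccc3)C2=O)c1` gives > 100000 nM in this assay.

Each of these values is a limit of this assay, not a number; compound 3 stands at that limit. The same holds for compound 1. The same holds for compound 2. Because every measured compound sits at the limit of > 100000 nM in this assay, at which 3 of the 3 values shown sit, none of the steps among them can be read: a step that the two limits leave unreadable from compound 1 to compound 2, a step that the two limits leave unreadable from compound 1 to compound 3 and a step that the two limits leave unreadable from compound 2 to compound 3 all remain unreadable, so the size of any change at this position of the anilide ring is unknown from the data shown.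

Compound 4 `O=C(Nc1ccc(OC(F)F)cc1)c1cccc(/C=C2\CC(=O)N(c3ccccc3)C2=O)c1` differs from compound 3 by difluoromethoxy in place of fluoro on an aromatic carbon. Going by the values given here, no measured step bears on this change beyond showing that the three neighbours of compound 4 all lie at the limit of this assay. On that basis compound 4 is expected to behave like compound 3, with an expected step that the limit leaves unreadable from compound 3 to compound 4, most probably again reported only as a limit. The estimate for compound 4 in this assay is 150000 nM, with a range from 50000 nM to 500000 nM.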

Compound 4, half-maximal inhibitory concentration: > 100000 nM
Compound 4: a limit, no number (the forecaster's own chance of this, stated with the estimate: 85%); the middle value does not contradict the limit.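

In this assay compound 4 gives > 100000 nM, a limit and not a number. No step among compound 1, compound 2, compound 3 and compound 4 can be read, since all four sit at the same limit: the limit of > 100000 nM in this assay, at which 4 of the 4 values shown sit.

The compounds shown leave open what their actual half-maximal inhibitory concentrations are, and whether exchanging these groups changes them at all.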